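Pyrimidine on the Core: Expecting Compound 4

The compounds below may be only part of what the source reports. "The series", "measured", "known", "first", "only" and "open" are said of these compounds alone.

Three hydroxamic acids share one core and were tested in an assay on Sf9 cells for inhibition of protein deacetylase HDAC6 (Homo sapiens), read by fluorescence; a higher number here means a weaker inhibitor, a lower number a stronger inhibitor. Compound 1 `O=C(NO)c1ccc(Cn2nnc(Cc3ccccc3)n2)cc1` gives 52 nM. Compound 2 `O=C(NO)c1ccc(Cn2nnc(Cc3ccccn3)n2)cc1` gives 25 nM, and compound 3 `O=C(O)c1cccc(-c2nnn(Cc3ccc(C(=O)NO)cc3)n2)c1` gives 12 nM. Among these three numbers compound 2 stands second highest: compound 1 lies above it and compound 3 below it, each separated from it by a step beyond the usual scatter.

Going by the values given here, the one measured step that changes a single place is a 2.1-fold lower number from compound 1 to compound 2 (0.32 log units; beyond the scatter), a modest gain from swapping phenyl for pyridin-2-yl on a saturated chain carbon.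

Compound 4 `O=C(NO)c1ccc(Cn2nnc(-c3ncccn3)n2)cc1` is not yet measured. It differs from compound 2 by pyrimidin-2-yl in place of (pyridin-2-yl)methyl on an aromatic carbon. Among the compounds with values here, this is a bigger change than the one from compound 1 to compound 2: a second ring nitrogen enters and the ring sits on the aromatic carbon of the core, as the ring of compound 3 does. Within the data shown here, no measured step has exactly this form. The step from compound 1 to compound 2 shows a modest improvement on adding a ring nitrogen, and compound 3, whose ring also sits on an aromatic carbon, has the lowest of the three numbers. Compound 4 is therefore expected to show a step of about a 1.4-fold lower number from compound 2 to compound 4 (0.14 log units; within the scatter), toward a somewhat lower number, though it could stay within scatter. The estimate for compound 4 is 18 nM, ranging from 7 nM to 45 nM.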

Compound 4, half-maximal inhibitory concentration: 7 nM
Estimate against measurement, compound 4: 2.6-fold (0.41 log units) above; low and high end bracket the measured number.
By their numbers in this assay, from the lowest: compounds 4 and 3 (each within the scatter of the next); then compound 2; then compound 1.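

In this assay, pyrimidin-2-yl in place of (pyridin-2-yl)methyl on the aromatic carbon of the shared core gives a 3.6-fold lower number from compound 2 to compound 4 (0.55 log units; beyond the scatter), and the same group in place of benzyl gives a 7.4-fold lower number from compound 1 to compound 4 (0.87 log units; beyond the scatter). Going by these compounds alone, the earlier single-place step changed only the ring on a saturated chain carbon, whereas this one shows that the position also accepts a ring bound straight to the aromatic carbon, with a number that lies within the scatter of the one for compound 3. The change does two things at once, removing the chain carbon and bringing a second ring nitrogen, and nothing measured here explains why the number falls.

From the compounds shown here alone, the size of each part therefore stays open: pyridin-2-yl on the aromatic carbon, or (pyrimidin-2-yl)methyl in the same place, would each separate the chain carbon from the ring nitrogen. Going by these compounds, whether the trend reaches beyond these rings also stays open, for instance with an amine or a longer chain at this position.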